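Sulfamide Amine Replaced by Difluorophenoxy on the Sulfonyl

The source may hold more compounds than are shown below. What is called first, only, known or untested is meant among the compounds shown, and "the series" means these compounds.

Measured so far:
compound 1, `CC(C)c1cccc(C(C)C)c1OC(=O)NS(=O)(=O)N1CCCCC1`: > 100000 nM
compound 2, `CCCCCCCCN(CCCCCCCC)S(=O)(=O)NC(=O)Oc1c(C(C)(C)C)cc(C)cc1C(C)(C)C`: 2700 nM

Of the compounds shown here, two have been tested in an assay on liver for inhibition of sterol O-acyltransferase 1 (Rattus norvegicus), using microsomes; on this read-out lower numbers stand for stronger inhibition and higher numbers for weaker inhibition. For compound 1 the reading > 100000 nM is a limit of the assay and not a number. Compound 1 therefore sits at the limit of > 100000 nM in this assay, at which 1 of the 2 values shown sits, so only its weak end is known. Going by the values given here, compound 2 gives 2700 nM in this assay, a measured number, but no single-point step links it to compound 1, and the two values show only that compound 2 is the one with a number.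

Compound 3, `CC(C)c1cccc(C(C)C)c1OC(=O)NS(=O)(=O)Oc1c(F)cccc1F`, has not been measured. It differs from compound 1 in one place: 2,6-difluorophenoxy in place of piperidin-1-yl on a sulfonyl sulfur. With compound 1 at a limit, the size of this step cannot be read from measured pairs. The expectation is a gain in inhibition for compound 3, expressed as a step of an at least 3.3-fold lower number from compound 1 to compound 3 (0.52 log units; beyond the scatter) from the limit. Compound 3 is estimated at 30000 nM, with a range from 5000 nM to 150000 nM, and a fair chance that only a limit is again reported.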

Compound 3, half-maximal inhibitory concentration: 38000 nM
Compound 3: the middle estimate sits 1.3-fold (0.10 log units) below what was measured; low and high end bracket the measured number.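

In this assay compound 1 gives > 100000 nM, a limit of the assay and not a number, so on its own it could not show whether the group on this sulfonyl sulfur can shift the read-out at all. Putting 2,6-difluorophenoxy in place of piperidin-1-yl gives an at least 2.6-fold lower number from compound 1 to compound 3 (0.42 log units; beyond the scatter), so this position does respond to change, and the core of compound 1 can give a measured number. The step is only a lower bound, and the true gain could be larger: the limit of > 100000 nM in this assay, at which 1 of the 3 values shown sits.

The compounds shown leave open which part of the new group carries the gain: the ring, the oxygen joining it to the sulfur, or the two fluorines. A plain phenoxy group without fluorine on the same core would help separate these.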